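A few compounds are considered here, and "the series" means these few. Any claim that something is new, unique, unknown or untested is made for them only; others in the source may bear on it.

Among the measured compounds shown here, in a functional assay on WM1361 cells (Homo sapiens) for inhibition, read by MTT assay, with a stated time of 24 h (on this read-out lower numbers stand for stronger inhibition and higher numbers for weaker inhibition), two compounds that share one core have numbers so far. Compound 1 (`COc1cccc(N2CCN(c3c(CO)c(=O)oc4ccccc34)CC2)c1`) gives 38100 nM and compound 2 (`O=c1oc2ccccc2c(N2CCN(C(c3ccc(F)cc3)c3ccc(F)cc3)CC2)c1CO`) gives 29400 nM. For the measured compounds named here, these two values lie within the scatter of each other, so compound 1 stands level with the only other number available.

Compound 3 (`COc1ccccc1N1CCN(c2c(CO)c(=O)oc3ccccc23)CC1`) differs from compound 1 in one place: 2-methoxyphenyl in place of 3-methoxyphenyl on an amine nitrogen in a ring. Going by the values given here, no measured pair shows what this exchange does on its own. Compound 2, which carries a different group on that amine nitrogen, still gives 29400 nM, within the scatter of compound 1 at 38100 nM. On that basis, no step beyond the scatter is expected in this assay, and no direction is favoured. The expected step is a 1.2-fold lower number from compound 1 to compound 3 (0.06 log units; within the scatter). For compound 3 the estimated value is 33000 nM, with an expected range from 14000 nM to 75000 nM.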

Compound 3, half-maximal inhibitory concentration: > 50000 nM
Compound 3 ended at the assay's limit; the forecaster's own chance of this, stated with the estimate: 10%; at least 1.5-fold (0.18 log units) between middle value and limit.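

In this assay, compound 3 gives > 50000 nM, which is a limit of the assay and not a number. Among the compounds shown here, exchanging 3-methoxyphenyl for 2-methoxyphenyl on an amine nitrogen in a ring gives an at least 1.3-fold higher number from compound 1 to compound 3 (0.11 log units; that floor lies within the scatter), the first step that can be read for a change at this place, and only its floor is known: the limit of > 50000 nM in this assay, at which 1 of the 3 values shown sits. The same atoms, joined differently, thus gave no lower number in this assay, although the floor alone does not establish a real rise.

From the compounds shown here alone, how a plain phenyl, a chlorophenyl or a pyridyl on that amine nitrogen would compare with the methoxyphenyl groups remains open. Going by these compounds, the true size of the step and what the methoxy group itself contributes also remain open.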